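The compounds below may be only part of what the source reports. "The series", "measured", "known", "first", "only" and "open" are said of these compounds alone.

The measured compounds, both in a functional assay on RAW264.7 cells (Mus musculus) for inhibition, read by Griess assay, with stated times of 1 h and 24 h; a lower number here means a stronger inhibitor, a higher number a weaker inhibitor:

Compound 1, `CCC(C)Oc1ccc(C(O)C2OC(=O)c3c(OC)cc(OC)cc32)cc1`. In this assay compound 1 gives > 10000 nM, which is a limit of the assay and not a number.

Compound 2, `CCOCCOc1ccc(C(O)C2OC(=O)c3c(OC)cc(OC)cc32)cc1`. In this assay compound 2 gives > 10000 nM, likewise a limit of the assay.

Compound 2 therefore stands at the limit of this assay, and it is not alone there: the limit of > 10000 nM in this assay, at which 2 of the 2 values shown sit. Going by the values given here, the only step that can be compared, a step that the two limits leave unreadable from compound 1 to compound 2, is 2-ethoxyethyl in place of sec-butyl on an oxygen on an aromatic ring, and with both ends at the limit its size cannot be read.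

The unmeasured compound 3 is `COc1cc(OC)c2c(c1)C(C(O)c1ccc(OCc3ccc(OC(F)(F)F)cc3)cc1)OC2=O`. It differs from compound 2 in that (4-(trifluoromethoxy)phenyl in place of ethoxymethyl on a saturated chain carbon bound to an oxygen on an aromatic ring). No measured step bears on this change, and the one step shown gives no size at all, so nothing in these numbers points to a direction. Compound 3 is expected to remain near the limit, with a chance of a readable number; the step expected from compound 2 to compound 3 in this assay is an at least 1.2-fold lower number from compound 2 to compound 3 (0.09 log units; that floor lies within the scatter), and the estimate for compound 3 is 8000 nM, with a range from 2000 nM to 30000 nM.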

Compound 3, half-maximal inhibitory concentration: 8140 nM
For compound 3 the middle estimate is 1.0-fold (0.01 log units) below the measured one, within the range that was stated.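

With the 4-(trifluoromethoxy)phenyl group on a saturated chain carbon bound to an oxygen on an aromatic ring, compound 3 gives the first readable number among these compounds in this assay, at 8140 nM, so a change at this position can bring a value inside the range of the assay. The change gives an at least 1.2-fold lower number from compound 2 to compound 3 (0.08 log units; that floor lies within the scatter), and because one end of this step is a limit, only its floor is known: the true size may be larger, but the floor alone does not establish a change beyond the scatter. The earlier step between sec-butyl and 2-ethoxyethyl cannot be read, and the other two compounds stay where they were: the limit of > 10000 nM in this assay, at which 2 of the 3 values shown sit.

The compounds shown leave open whether the aromatic ring alone or the trifluoromethoxy group on it goes with the readable number, as none of them carries a plain phenyl in that place. They also leave open how an amine or a carboxylic acid on the chain would read, and whether a change to the shared core would move the number further.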